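A few compounds are considered here, and "the series" means these few. Any claim that something is new, unique, unknown or untested is made for them only; others in the source may bear on it.

For the measured compounds named here, compound 2 `O=C(Nc1cc(-c2ccccc2)nn1-c1ccccc1)c1cccc(C(F)(F)F)c1` stands at the top of the two numbers so far: in an assay on HEK293 cells for displacement of a labelled ligand from metabotropic glutamate receptor 5 (Rattus norvegicus) (on this read-out higher numbers stand for weaker inhibition and lower numbers for stronger inhibition), compound 2 gives 1650 nM. Its nearest neighbour, compound 1 `COc1cccc(C(=O)Nc2cc(-c3ccccc3)nn2-c2ccccc2)c1`, gives in this assay a value of 1290 nM, and the step of a 1.3-fold higher number from compound 1 to compound 2 (0.11 log units; within the scatter) stays within the scatter, so the two compounds cannot be ranked against each other.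

The compound still to be measured is compound 3 `Cc1ccc(C(=O)Nc2cc(-c3ccccc3)nn2-c2ccccc2)cc1`. Relative to compound 2 the change is this: 4-methylphenyl in place of 3-(trifluoromethyl)phenyl on a carbonyl carbon. Going by the values given here, the only measured step available, a 1.3-fold higher number from compound 1 to compound 2 (0.11 log units; within the scatter), also exchanges one substituent on the benzamide ring for another, and it produced no shift beyond the scatter. Among the compounds with values here, no measured step addresses a methyl group or a change in substitution pattern, so the data give no basis for expecting movement in either direction.

On that footing, the step of a 1.1-fold lower number from compound 2 to compound 3 (0.04 log units; within the scatter) is expected to be small, with no direction beyond the scatter. For compound 3 the estimate in this assay is therefore 1500 nM, with a range from 500 nM to 4500 nM.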

Compound 3, inhibition constant: 780 nM
Compound 3: the middle estimate sits 1.9-fold (0.28 log units) above what was measured; measured number inside the range.
By their numbers in this assay, from the lowest: compounds 3, 1 and 2 (each within the scatter of the next, the first and the last beyond it).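

In this assay, for the compounds shown here, the aryl group on a carbonyl carbon whose other neighbours are amide-type nitrogen now shows an effect on the number, which the earlier pair did not show: 4-methylphenyl in place of 3-(trifluoromethyl)phenyl gives a 2.1-fold lower number from compound 2 to compound 3 (0.33 log units; beyond the scatter) and so produces the first step beyond the scatter, though only a modest one. The gain in separation is limited, since 4-methylphenyl in place of 3-methoxyphenyl gives a 1.7-fold lower number from compound 1 to compound 3 (0.22 log units; within the scatter) and stays within the scatter, so compound 3 stands apart from compound 2 but cannot be ranked against compound 1. No measurement at hand bears on why the step from compound 2 arises.

That step exchanges both the group and its place on the ring, so the compounds shown cannot say whether the methyl group, the loss of trifluoromethyl or the shift in substitution pattern accounts for it; 3-methylphenyl and 4-(trifluoromethyl)phenyl would separate these. From the compounds shown here alone, it also remains open how this position responds to an amine, a carboxylic acid or a longer chain such as 4-butylphenyl.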